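The source may report more compounds than this note shows. Statements on the series, on what has been measured and on what is new or still open speak of the compounds shown alone.

Compound 1 `NC(=O)c1ncn(CCC2(O)NC(=O)C(OCc3ccccc3)=C2OCc2ccccc2)n1`: 66000 nM
Compound 2 `COC(=O)c1ncn(CCC2(O)NC(=O)C(OCc3ccccc3)=C2OCc2ccccc2)c1C(=O)OC`: > 100000 nM

Among the measured compounds shown here, in a functional assay on HepG2 cells (Homo sapiens) for antiproliferative activity, read by MTT assay, with a stated time of 72 h (on this read-out higher numbers stand for weaker inhibition and lower numbers for stronger inhibition), compound 1 gives 66000 nM, the only plain number among the two measured compounds. Compound 2 reaches only the limit of this assay, > 100000 nM, which is a limit and not a number; this is the limit of > 100000 nM in this assay, at which 1 of the 2 values shown sits. For the measured compounds named here, no pair of measured compounds differs in one place, so no measured step is available, and compound 1 stands alone as the point of reference.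

Compound 3 `NC(=O)c1ncn(CCC2(O)NC(=O)C(OCc3ccccc3)=C2OCc2ccccc2)c1C(N)=O` has not yet been measured in this assay. It differs from compound 1 in one place: 4,5-dicarbamoyl-1H-imidazol-1-yl in place of 3-carbamoyl-1H-1,2,4-triazol-1-yl on a saturated chain carbon, two bonds along the chain from a saturated ring carbon. Without a measured step to lean on, the change is expected to stay within the usual scatter or, if anything, to run toward weaker inhibition. The expected step is a 1.3-fold higher number from compound 1 to compound 3 (0.11 log units; within the scatter). Compound 3 is therefore estimated at 85000 nM, in a range from 30000 nM to 250000 nM.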

Compound 3, half-maximal inhibitory concentration: > 100000 nM
Compound 3 gave a limit, no number (the forecaster's own chance of this, stated with the estimate: 45%); middle value at least 1.1-fold (0.07 log units) from the limit.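

In this assay compound 3 gives only a limit, not a number: the limit of > 100000 nM in this assay, at which 2 of the 3 values shown sit.

Among the compounds shown here, exchanging the group at the end of the chain provides the first readable step at this position: an at least 1.5-fold higher number from compound 1 to compound 3 (0.18 log units; that floor lies within the scatter). The change brought no stronger inhibition, but the floor of the step does not establish a real loss, and its full size cannot be read.

The compounds shown leave open how large the step really is. They also leave open whether an amine or a carboxylic acid in place of the carbamoyl group, or a longer chain to the same ring, would change the inhibition.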